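The source may hold more compounds than are shown below. What is called first, only, known or untested is meant among the compounds shown, and "the series" means these compounds.

Compounds measured so far:
compound 1, `C=C1C(=O)OC[C@H]1CCOC(=O)Nc1ccc(C(=O)OCCCC)cc1`, giving 430 nM;
compound 2, `C=C1C(=O)OC[C@H]1CCOC(=O)Nc1cc(C)cc(C)c1`, giving 480 nM;
compound 3, `C=C1C(=O)OC[C@H]1CCOC(=O)Nc1ccc(C)c(C)c1`, giving 1090 nM.

In a functional assay on RAW264.7 cells (Mus musculus) for inhibition, with a stated time of 30 min (a higher number here means a weaker inhibitor, a lower number a stronger inhibitor), compound 1 stands at the lowest of the three numbers. Compound 2 sits within the scatter of compound 1, so no order between the two can be claimed, while compound 3 lies beyond the scatter above compound 1. Compound 4, `C=C1C(=O)OC[C@H]1CCOC(=O)Nc1ccc(Cl)cc1`, differs from compound 1 in one place: chloro in place of butoxycarbonyl on an aromatic carbon. Among the measured compounds shown here, no step between measured compounds shares this change, so the only footing is the shared core and the carbamate that all three measured compounds keep. Compound 4 is therefore expected to land near compound 1, with an estimated step of a 1.4-fold higher number from compound 1 to compound 4 (0.14 log units; within the scatter) that may well stay within the scatter. The expected value for compound 4 is 600 nM, estimated to fall between 250 nM and 1500 nM.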

Compound 4, half-maximal inhibitory concentration: 390 nM
Estimate against measurement, compound 4: 1.5-fold (0.19 log units) above, and the stated range covers the measured number.
By their numbers in this assay, from the lowest: compounds 4, 1 and 2 (each within the scatter of the next); then compound 3.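

In this assay, chloro in place of butoxycarbonyl on this aromatic carbon, para to a large group, gives a 1.1-fold lower number from compound 1 to compound 4 (0.04 log units; within the scatter) and so no difference can be claimed between the two compounds. The whole butoxycarbonyl group, with its two hydrogen-bond acceptors, can thus give way to a single chlorine atom at this position without a measurable shift in the number. Nothing available explains this equivalence.

The compounds shown leave open whether a carboxylic acid or an amine at this position would read the same. They also do not show whether plain hydrogen there would keep the number in this range.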